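Working notes: defined to undefined stereocentre in the series

A few compounds are considered here, and "the series" means these few. Any claim that something is new, unique, unknown or untested is made for them only; others in the source may bear on it.

Three compounds of the shared core have numbers in a functional assay on CCRF-CEM cells (Homo sapiens) for antiproliferative activity, read by MTT assay, with a stated time of 24 h, tested at 12.5 uM; a lower number here means a stronger effect, a higher number a weaker effect of the compound at the concentration tested. Compound 1 `OC(CCn1nc2c(Br)c(Br)c(Br)c(Br)c2n1)c1cccc(Br)c1` gives 102%. Going by the values given here, compound 2 `COc1cccc(C(O)CCn2nc3c(Br)c(Br)c(Br)c(Br)c3n2)c1` gives 110% in this assay; the only measured single-point step, a number 8 percentage points higher from compound 1 to compound 2 (within the scatter), is within the scatter. Compound 3 `C[C@@H](O)CCn1nc2c(Br)c(Br)c(Br)c(Br)c2n1` gives 88% in this assay and stands lowest of the three numbers: compound 1 lies beyond the scatter above it, compound 2 further still.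

Compound 4 `CC(O)CCn1nc2c(Br)c(Br)c(Br)c(Br)c2n1` is not yet measured. The difference to compound 3 is the two compounds have the same atoms and bonds; at least one stereo element is drawn with a configuration in one of them and without one in the other: 1 of 1 stereo elements differ; a stereocentre at a saturated chain carbon is drawn R in compound 3 and without a configuration in compound 4. Among the compounds with values here, no measured step concerns a stereocentre: the one step on record, which swaps an aromatic substituent, has no bearing here. Compound 4 keeps the same atoms and bonds as compound 3, so its number in this assay is expected to sit close to that of compound 3, with no step beyond the scatter expected: a number 3 percentage points higher from compound 3 to compound 4 (within the scatter). For compound 4 the estimate is 91%, with a range from 79% to 103%.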

Compound 4, a percentage reported as activity, at one concentration (the size of the read-out at that concentration, not a potency): 106%
Compound 4: the middle estimate sits 15 percentage points below what was measured, outside the stated range (above it).
By their numbers in this assay, from the lowest: compound 3; then compounds 1, 4 and 2 (each within the scatter of the next).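

In this assay, a change in which nothing enters or leaves now gives a step beyond the scatter (a number 18 percentage points higher from compound 3 to compound 4 (beyond the scatter)), so the way the stereocentre at the saturated chain carbon is drawn cannot be set aside for this pair. The only structural ground for that step is this: the fact that one of compounds 3 and 4 is drawn with a defined configuration and the other without, at the place where they differ. With no configuration drawn, methyl in place of 3-methoxyphenyl (a number 4 percentage points lower from compound 2 to compound 4 (within the scatter)) and methyl in place of 3-bromophenyl (a number 4 percentage points higher from compound 1 to compound 4 (within the scatter)) both stay within the scatter, so these exchanges do not separate the compounds at this concentration.

The compounds shown leave open how a form drawn S would read in this assay. They also leave open whether an amine or a carboxylic acid in place of the hydroxyl, or a longer chain, would keep the number of compound 3.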